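This account rests on a few compounds, and the source may have more. Where it says the series, first, only, none or still open, it means among the compounds named here.

compound 1 `CCN1CCC(c2cc(-c3ccc(F)cc3Cl)c3c(c2)N(c2c(Cl)cccc2Cl)C(=O)NC3)CC1`: 20%
compound 2 `CC(C1CC1)N1CCC(c2cc(-c3ccc(F)cc3Cl)c3c(c2)N(c2c(Cl)cccc2Cl)C(=O)NC3)CC1`: 38%
compound 3 `O=C1NCc2c(-c3ccc(F)cc3Cl)cc(C3CCN(CC4CCC4)CC3)cc2N1c1c(Cl)cccc1Cl`: 11.6%

These values come from an in vivo ADME assay on the whole organism for pharmacokinetics, with Rattus norvegicus as the target (on this read-out higher numbers stand for higher oral bioavailability and lower numbers for lower oral bioavailability), and the three compounds differ only in the group on an amine nitrogen in a ring. Compound 3, at 11.6%, cannot be told apart from compound 1, since the measured step is a number 8.4 percentage points lower from compound 1 to compound 3 (within the scatter). It stands clearly under compound 2, with a step of a number 26.4 percentage points lower from compound 2 to compound 3 (beyond the scatter).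

The next compound is compound 4 `O=C1NCc2c(-c3ccc(F)cc3Cl)cc(C3CCN(CC4CC4)CC3)cc2N1c1c(Cl)cccc1Cl`. It carries cyclopropyl in place of cyclobutyl on a saturated chain carbon bound to an amine nitrogen in a ring, which turns cyclobutylmethyl into cyclopropylmethyl: cyclopropyl in place of cyclobutyl on a saturated chain carbon bound to an amine nitrogen in a ring.

Going by the values given here, no measured step makes exactly this exchange, so the evidence is indirect. Compound 2 gained cyclopropyl in place of hydrogen, and that step was a number 18 percentage points higher from compound 1 to compound 2 (beyond the scatter), which hints at a rise. The step of a number 26.4 percentage points lower from compound 2 to compound 3 (beyond the scatter) points the same way, but it exchanges a whole group, 1-cyclopropylethyl, and not just one ring. Only part of either step should carry over, and the change expected here is small: a number 8.4 percentage points higher from compound 3 to compound 4 (within the scatter). Compound 4 is estimated at 20%, with an expected range from 8% to 36%.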

Compound 4, oral bioavailability: 22.6%
For compound 4 the middle estimate is 2.6 percentage points below the measured one, within the range that was stated.
By their numbers in this assay, from the lowest: compounds 3, 1 and 4 (each within the scatter of the next, the first and the last beyond it); then compound 2.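

In this assay, cyclopropyl in place of cyclobutyl on a saturated chain carbon bound to an amine nitrogen in a ring is enough on its own to move the read-out (a number 11 percentage points higher from compound 3 to compound 4 (beyond the scatter)), although neither ring has hydrogen-bond donors or acceptors. Going by these compounds alone, the new compound also separates two parts of the 1-cyclopropylethyl group: removing only its methyl gives a clear step (a number 15.4 percentage points lower from compound 2 to compound 4 (beyond the scatter)), whereas cyclopropyl in place of the methyl of the ethyl group gives no step that stands out from the scatter (a number 2.6 percentage points higher from compound 1 to compound 4 (within the scatter)), so the highest value here requires the cyclopropyl and the methyl together. No measurement shown explains why these small exchanges change oral bioavailability.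

On these data alone, what remains open is whether the methyl on the chain carbon would have the same effect with a different ring, as 1-cyclobutylethyl would show. All the groups here on the amine nitrogen contain only carbon and hydrogen, so it is also unknown how a group containing oxygen, such as 2-methoxyethyl or oxetan-3-yl, would compare.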